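The source may hold more compounds than are shown below. What is called first, only, known or untested is meant among the compounds shown, and "the series" means these compounds.

The measured compounds and their numbers in a functional assay on U-937 cells (Homo sapiens) for antiproliferative activity, read by CCK-8 assay, with a stated time of 24 h; a lower number here means a stronger inhibitor, a higher number a weaker inhibitor:
compound 1, `Cc1ccc(NC(=O)c2ccc(CN3CCCN(C)CC3)cc2)cc1-n1cc(-c2cnc3ccnn3c2)cn1`, gives 6830 nM;
compound 2, `Cc1ccc(NC(=O)c2cccc(C(F)(F)F)c2)cc1-n1cc(-c2cnc3cccnn23)cn1`, gives 13700 nM;
compound 3, `COc1ccc(C(=O)Nc2ccc(C)c(-n3cc(-c4cnc5ccnn5c4)cn3)c2)cc1`, gives 16300 nM.

Compound 2 holds the second highest of the three numbers in this assay, yet its gap to compound 3 and its gap to compound 1 both lie within the scatter of repeated measurements, so no order among these three can be read from its value. For the measured compounds named here, the only step between two compounds that differ in one place, a 2.4-fold higher number from compound 1 to compound 3 (0.38 log units; beyond the scatter), exchanges one group for another on the aromatic ring joined to the carbonyl and is modest. Compound 4, `Cc1ccc(NC(=O)c2ccc(F)cc2)cc1-n1cc(-c2cnc3cccnn23)cn1`, keeps the core of compound 2 and differs from it by 4-fluorophenyl in place of 3-(trifluoromethyl)phenyl on a carbonyl carbon. Going by the values given here, no measured pair repeats this change; the step from compound 1 to compound 3 is the nearest guide and was modest, so a step of similar or smaller size is expected here, in no firm direction. Compound 4 is therefore expected to give 12000 nM in this assay, between 5000 nM and 30000 nM. That estimate means a 1.1-fold lower number from compound 2 to compound 4 (0.06 log units; within the scatter), expected to stay within the scatter.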

Compound 4, half-maximal inhibitory concentration: > 20000 nM
Compound 4 ended at the assay's limit (the forecaster's own chance of this, stated with the estimate: 15%); middle value at least 1.6-fold (0.22 log units) away from the limit.
By their numbers in this assay, from the lowest: compounds 1, 2 and 3 (each within the scatter of the next, the first and the last beyond it). At a limit, above all of these: compound 4.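

In this assay compound 4 gives > 20000 nM, a limit of the assay and not a number, and the only such reading among the compounds shown: the limit of > 20000 nM in this assay, at which 1 of the 4 values shown sits. The earlier compounds shown here held no single change on the core of compound 2, and this one, on a carbonyl carbon whose other neighbour is an amide-type nitrogen, comes to an at least 1.4-fold higher number from compound 2 to compound 4 (0.16 log units; that floor lies within the scatter). That floor lies within the scatter, so 4-fluorophenyl in place of 3-(trifluoromethyl)phenyl establishes no firm loss, shows no gain, and leaves the true size of the step unbounded on the upper side.

Open, from the compounds shown here alone, is how a carboxylic acid or a nitrile on that phenyl ring would read on the core of compound 2. Also open, going by these compounds, is whether an amine such as the (4-methyl-1,4-diazepan-1-yl)methyl group of compound 1 would read the same there as on its own core.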